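Pyrimidine for Pyridine on an Amide Nitrogen: Expected Effect

The compounds below may be only part of what the source reports. "The series", "measured", "known", "first", "only" and "open" are said of these compounds alone.

Compound 1, `O=C1c2cc(COc3ccccc3)nn2CCN1c1cccnc1`: 64%
Compound 2, `O=C1c2cc(COc3ccccc3)nn2CCN1c1ccc(F)cn1`: 72%

Within the data shown here, in a functional assay on HEK293 cells for positive allosteric modulation of metabotropic glutamate receptor 5 (Homo sapiens), read by calcium flux (on this read-out lower numbers stand for smaller maximal responses and higher numbers for larger maximal responses), compound 2 holds the highest of the two numbers, and its nearest neighbour compound 1 lies within the scatter of it; the only measured step is a number 8 percentage points higher from compound 1 to compound 2 (within the scatter). Compound 3, `O=C1c2cc(COc3ccccc3)nn2CCN1c1ncc(F)cn1`, has not been measured. It differs from compound 2 by 5-fluoropyrimidin-2-yl in place of 5-fluoropyridin-2-yl on an amide-type nitrogen in a ring. That single measured step concerns a different exchange and was itself within the scatter, so no shift beyond the scatter is expected here; the expected step is a number 2 percentage points lower from compound 2 to compound 3 (within the scatter). Compound 3 is estimated at 70%, within 55% to 85%.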

Compound 3, largest response reached (Emax), in percent of the reference or control that the assay uses: 72%
Compound 3: middle estimate off by 2 percentage points, on the low side; the measured number falls inside the stated range.
By their numbers in this assay, from the lowest: compounds 1, 2 and 3 (each within the scatter of the next).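

In this assay, a second ring nitrogen in the aromatic group on the amide-type nitrogen gives no change at the digits printed from compound 2 to compound 3 (within the scatter), so 5-fluoropyrimidin-2-yl serves here as well as 5-fluoropyridin-2-yl. Measured against pyridin-3-yl, it gives a number 8 percentage points higher from compound 1 to compound 3 (within the scatter), which places all three aromatic groups at this position within the scatter of one another. Nothing available explains this result. Still open, from the compounds shown here alone, is whether a plain phenyl ring or a morpholine would hold the response at this position, and whether a chlorine or a methoxy group could replace the fluorine on the pyrimidine.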